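Moving a Methoxy Group Around the Phenyl Ring

A few compounds are considered here, and "the series" means these few. Any claim that something is new, unique, unknown or untested is made for them only; others in the source may bear on it.

Of the compounds shown here, three sharing one core have been measured so far in a functional assay on KBVIN cells (Homo sapiens) for antiproliferative activity, read by sulforhodamine B assay, with a stated time of 3 days (on this read-out lower numbers stand for an effect already at smaller amounts and higher numbers for an effect only at larger amounts of compound), and can be compared directly. Compound 1 `CCC1=C(O)c2c(oc(-c3ccc(CBr)cc3)cc2=O)C(CC)(CC)C1=O` carries 4-(bromomethyl)phenyl and gives 27.9 uM on this scale. Compound 2 `CCC1=C(O)c2c(oc(-c3cccc(C)c3)cc2=O)C(CC)(CC)C1=O` carries 3-methylphenyl and gives 3.69 uM on the same scale. Compound 3 `CCC1=C(O)c2c(oc(-c3cccc(OC)c3)cc2=O)C(CC)(CC)C1=O` carries 3-methoxyphenyl and gives 1.22 uM as the lowest of the three numbers.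

Compound 4 `CCC1=C(O)c2c(oc(-c3ccccc3OC)cc2=O)C(CC)(CC)C1=O` has not yet been measured. It has the same atoms as compound 3 joined differently, with 2-methoxyphenyl in place of 3-methoxyphenyl on an aromatic carbon.

The measured steps bear on this change only indirectly. The closest is a 3.0-fold lower number from compound 2 to compound 3 (0.48 log units; beyond the scatter) for methoxy in place of methyl, a modest step. Replacing 4-(bromomethyl)phenyl gives a 7.6-fold lower number from compound 1 to compound 2 (0.88 log units; beyond the scatter) as another modest step and a 23-fold lower number from compound 1 to compound 3 (1.36 log units; beyond the scatter) as a large one. Going by the values given here, none of these steps moves a methoxy group, so they show only that changing this phenyl group can shift the number.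

Compound 3 at 1.22 uM already holds the lowest number, so a slight rise seems the likelier direction. The expected change is a 1.6-fold higher number from compound 3 to compound 4 (0.21 log units; within the scatter) and is not expected to pass beyond the scatter. Compound 4 is estimated at 2 uM with an expected range from 0.6 uM to 8 uM once it is measured.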

Compound 4, concentration for half-maximal effect: 3.26 uM
Estimate against measurement, compound 4: 1.6-fold (0.21 log units) below, and the stated range covers the measured number.
By their numbers in this assay, from the lowest: compound 3; then compounds 4 and 2 (each within the scatter of the next); then compound 1.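

In this assay, the place of the methoxy group on the phenyl ring matters on its own: compounds 3 and 4 have the same atoms joined differently, yet the move to 2-methoxyphenyl separates them beyond the usual scatter (a 2.7-fold higher number from compound 3 to compound 4 (0.43 log units; beyond the scatter)). The gain seen earlier for methoxy over methyl therefore does not hold for every placement, since compound 4 cannot be told apart from the 3-methylphenyl compound (a 1.1-fold lower number from compound 2 to compound 4 (0.05 log units; within the scatter)), although it still differs clearly from the 4-(bromomethyl)phenyl compound (an 8.6-fold lower number from compound 1 to compound 4 (0.93 log units; beyond the scatter)). Nothing available here explains why this shift in the methoxy group changes the number.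

From the compounds shown here alone, what a 4-methoxyphenyl group would give remains open, so the three possible placements of methoxy on this ring cannot yet be compared in full. Going by these compounds, it is also open whether the same shift from the 3-position to the 2-position would matter for other groups, such as an amine, a carboxylic acid or a longer chain like propoxy, because only the methoxy pair speaks to this change.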